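Working notes on the methylphenyl amine series, paw edema

The source may hold more compounds than are shown below. What is called first, only, known or untested is meant among the compounds shown, and "the series" means these compounds.

Measured so far:
compound 1 `Cc1ccc(/C=C2\CCCC(CN(C)c3ccccc3)C2=O)cc1` gives 44.7%
compound 2 `Cc1cccc(N(C)CC2CCC/C(=C\c3ccc(S(C)(=O)=O)cc3)C2=O)c1` gives 36.2%
compound 3 `Cc1ccc(N(C)CC2CCC/C(=C\c3ccccc3)C2(O)c2ccccc2)cc1` gives 59.6%

All three values come from a functional assay on the whole organism (strain Wistar) for inhibition, with Rattus norvegicus as the target, read by paw edema, with stated times of 1 h and 3 h, at a dose of 200 mg/kg by the oral route; on this read-out higher numbers stand for more inhibition at the one dose given (going by the name of the read-out) and lower numbers for less inhibition. Compound 3 stands highest of the three numbers. Its nearest neighbour is compound 1, lower by a margin beyond the scatter; compound 2 lies furthest below it, also beyond the scatter. No two of the measured compounds differ in one place only, so no measured step can be read off directly.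

Compound 4 `Cc1cccc(N(C)CC2CCC/C(=C\c3ccccc3)C2(O)c2ccccc2)c1` is the next compound to be measured. It differs from compound 3 in one place: 3-methylphenyl in place of 4-methylphenyl on an amine nitrogen. Compound 2 also carries a methyl(3-methylphenyl)amino group, but it differs from compound 3 elsewhere as well, so its value cannot be ascribed to this change alone. Within the data shown here, with no matched step to lean on, the expectation is a step of a number 4.6 percentage points lower from compound 3 to compound 4 (within the scatter), that is none beyond the scatter. Compound 4 is therefore expected to give about 55% in this assay, within a range of 40% to 70%.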

Compound 4, a percentage reported as inhibition, in the whole organism at one dose (the size of the read-out at that dose, not a potency): 36.2%
The estimate for compound 4 lay 18.8 percentage points above the measured number, outside the stated range (below it).
By their numbers in this assay, from the lowest: compounds 2, 4 and 1 (each within the scatter of the next); then compound 3.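

In this assay, among these compounds, 3-methylphenyl in place of 4-methylphenyl on an amine nitrogen gives a number 23.4 percentage points lower from compound 3 to compound 4 (beyond the scatter), the first step that can be read from a single change. At this place, then, methyl(4-methylphenyl)amino and methyl(3-methylphenyl)amino are not interchangeable on the core of compound 3, even though the two compounds hold the same atoms. Nothing at hand bears on what lies behind this step.

Among the compounds shown here, whether a step of this size carries over to the core of compound 2 stays open, since the one matched pair shares the core of compound 3. Also open, from the compounds shown here alone, is how a chlorophenyl or a methoxyphenyl group on the same amine nitrogen would compare with the two methylphenyl groups.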